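This account rests on a few compounds, and the source may have more. Where it says the series, first, only, none or still open, it means among the compounds named here.

Three related compounds have been tested in an ADME assay on microsomes from liver (Mus musculus) for metabolic stability, using NADPH, with a stated time of 60 min, in the presence of a further agent that is not named here; on this read-out lower numbers stand for slow clearance and higher numbers for fast clearance. Compound 1 `CC(=O)NC1C2CC3CC1CC(C2)C31OO[C@]2(CC[C@@H](c3ccc(OCC(=O)O)cc3)CC2)O1` gives < 7 mL.min-1.g-1, which is a limit of the assay and not a number. Compound 3 `O=C(O)CN1CCC(Oc2ccc([C@H]3CC[C@]4(CC3)OOC3(O4)C4CC5CC(C4)CC3C5)cc2)CC1` gives < 7 mL.min-1.g-1, which is also only a limit. Compound 3 therefore stands at the limit of < 7 mL.min-1.g-1 in this assay, at which 2 of the 3 values shown sit. Compound 2 `O=C(O)c1cc([C@H]2CC[C@]3(CC2)OOC2(O3)C3CC4CC(C3)CC2C4)ccc1O` is the only one of the three with a true number, 20 mL.min-1.g-1.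

Compound 4 `O=C(O)CCCOc1ccc([C@H]2CC[C@]3(CC2)OOC2(O3)C3CC4CC(C3)CC2C4)cc1` differs from compound 3 on an oxygen on an aromatic ring, where 3-carboxypropyl takes the place of 1-(carboxymethyl)piperidin-4-yl: 3-carboxypropyl in place of 1-(carboxymethyl)piperidin-4-yl on an oxygen on an aromatic ring. Within the data shown here, no pair of measured compounds shows what a single change of this kind does, so any expectation is loose. Compound 1 also carries an open chain ending in an acid on such an oxygen, and its result is the limit < 7 mL.min-1.g-1. The expected change is small and upward, an at least 1.4-fold higher number from compound 3 to compound 4 (0.15 log units; that floor lies within the scatter), and this estimate may prove to lie within the scatter. Compound 4 is expected to give about 10 mL.min-1.g-1, with an estimated range from 5 mL.min-1.g-1 to 25 mL.min-1.g-1.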

Compound 4, intrinsic clearance in microsomes: 8 mL.min-1.g-1
Compound 4: middle estimate off by 1.3-fold (0.10 log units), on the high side; low and high end bracket the measured number.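

Among these compounds, this is the first step read at this position: on an oxygen on an aromatic ring, 3-carboxypropyl in place of 1-(carboxymethyl)piperidin-4-yl gives, in this assay, an at least 1.1-fold higher number from compound 3 to compound 4 (0.05 log units; that floor lies within the scatter). The open chain without a ring therefore comes with a true number in compound 4, 8 mL.min-1.g-1. The step's floor alone shows no change beyond the usual scatter. The real size of the step may be larger and cannot be fixed, because compound 3 stands only at an assay limit: the limit of < 7 mL.min-1.g-1 in this assay, at which 2 of the 4 values shown sit.

The two compounds do not separate the loss of the piperidine ring from the change in chain between that ring's nitrogen and the acid. A longer chain ending in a carboxylic acid, or an amine on the same oxygen, would leave open how much each part contributes.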